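This account rests on a few compounds, and the source may have more. Where it says the series, first, only, none or still open, it means among the compounds named here.

Of the compounds shown here, three have so far been tested in an ADME assay on WI-38 cells (Homo sapiens) for cytotoxicity, read by MTT assay, with a stated time of 3 days; a higher number here means a weaker inhibitor, a lower number a stronger inhibitor. Compound 1 `CCCCC#Cc1cn(C/C=C/CN2C(=O)c3ccccc3C2=O)c(=O)[nH]c1=O` gives 35000 nM. Compound 2 `CCCCc1ccc(C#Cc2cn(C/C=C\CN3C(=O)c4ccccc4C3=O)c(=O)[nH]c2=O)cc1` gives 17000 nM. Compound 3 `CCCCCCCCC#Cc1cn(C/C=C/CN2C(=O)c3ccccc3C2=O)c(=O)[nH]c1=O` gives 53000 nM, the highest of the three numbers; its nearest neighbour is compound 1, and the step from compound 1 to compound 3 is a 1.5-fold higher number from compound 1 to compound 3 (0.18 log units; within the scatter), a change in which butyl replaces hydrogen on a saturated chain carbon, four bonds along the chain from a triple-bonded carbon. The furthest value from compound 3 is that of compound 2, and that gap lies beyond the scatter.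

Compound 4 `CCCCc1ccc(C#Cc2cn(C/C=C/CN3C(=O)c4ccccc4C3=O)c(=O)[nH]c2=O)cc1` has not yet been measured. It differs from compound 3 in this way: 4-butylphenyl in place of octyl on a triple-bonded carbon. For the measured compounds named here, only one measured step is available, the one from compound 1 to compound 3, and it concerns a change of chain length rather than a ring entering, so it says little about the present change. More telling is that compound 2 also carries a 4-butylphenyl on a triple-bonded carbon and gives a clearly lower number than compound 3. The step from compound 3 to compound 4 is therefore expected to be a 2.7-fold lower number from compound 3 to compound 4 (0.42 log units; beyond the scatter). Compound 4 is estimated to give 20000 nM, within the range 8000 nM to 50000 nM.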

Compound 4, half-maximal inhibitory concentration: 40000 nM
For compound 4 the middle estimate is 2.0-fold (0.30 log units) below the measured one; the measured number falls inside the stated range.
By their numbers in this assay, from the lowest: compound 2; then compounds 1, 4 and 3 (each within the scatter of the next).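

Putting 4-butylphenyl in place of octyl on a triple-bonded carbon gives a 1.3-fold lower number from compound 3 to compound 4 (0.12 log units; within the scatter) and putting it in place of butyl at the same carbon gives a 1.1-fold higher number from compound 1 to compound 4 (0.06 log units; within the scatter). In this assay the entry of this aromatic ring therefore does not separate compound 4 from compound 1 or compound 3, whichever chain it replaces. The step that does lie beyond the scatter, though only modestly, is a 2.4-fold higher number from compound 2 to compound 4 (0.37 log units; beyond the scatter) and it involves the double bond alone, so the lower number of compound 2 goes with the Z form and not with the 4-butylphenyl group: the fact that compounds 2 and 4 differ only in the configuration as drawn.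

Whether a double bond drawn Z also goes with a lower number when butyl or octyl sits on the triple-bonded carbon stays open, as the only E and Z pair shown carries 4-butylphenyl. Also open, going by these compounds, is whether an amine or a carboxylic acid in place of 4-butylphenyl on a triple-bonded carbon would move the number beyond the scatter.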